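The compounds below may be only part of what the source reports. "The series", "measured", "known", "first", "only" and "open" are said of these compounds alone.

Measured in a functional assay on DLD-1 cells (Homo sapiens) for antiproliferative activity, read by CellTiter-Glo, with a stated time of 72 h; on this read-out lower numbers stand for stronger inhibition and higher numbers for weaker inhibition:
Compound 1 `Cc1cccc(S(=O)(=O)N2CCC(N3CCC(C)CC3)CC2)c1`: 25 nM
Compound 2 `CC1CCN(C2CCN(S(=O)(=O)c3nccn3C)CC2)CC1`: > 5000 nM (a limit of the assay, not a number)

Only these two compounds have been measured, and compound 2 sits at the limit of > 5000 nM in this assay, at which 1 of the 2 values shown sits. Its true value is therefore not known.

Compound 3 `CC1CCN(C2CCN(S(=O)(=O)c3cn(C)cn3)CC2)CC1` keeps the shared core of compound 2 and differs only on a sulfonyl sulfur whose other neighbours are a sulfonamide nitrogen in a ring: 1-methyl-1H-imidazol-4-yl in place of 1-methyl-1H-imidazol-2-yl on a sulfonyl sulfur. The two have the same atoms, joined differently.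

Among the compounds with values here, one measured step bears on this change, and it is large: an at least 200-fold higher number from compound 1 to compound 2 (2.30 log units; beyond the scatter), with 1-methyl-1H-imidazol-2-yl in place of 3-methylphenyl. Compound 3 also lacks the 3-methylphenyl group, so the loss seen in that step is expected to persist. Within the data shown here, no measurement yet compares the two imidazole attachments directly. In this assay, the expected result is no change beyond the scatter, with no favoured direction: a number no higher from compound 2 to compound 3 (the limit leaves the size open). Compound 3 may well be reported only as a limit too. For compound 3 the estimated value is 5000 nM, with an expected range from 1500 nM to 15000 nM.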

Compound 3, half-maximal inhibitory concentration: > 5000 nM
Compound 3: only a limit was reported (the forecaster's own chance of this, stated with the estimate: 70%); the middle value lies on the limit itself.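

In this assay, replacing the 3-methylphenyl group with 1-methyl-1H-imidazol-4-yl gives an at least 200-fold higher number from compound 1 to compound 3 (2.30 log units; beyond the scatter). The loss at this position is therefore not tied to a single imidazole attachment: compound 2 and compound 3 have the same atoms, joined differently, yet each is reported only as a limit of the assay, not as a number. Two of the three compounds now share that limit, and both carry an imidazole group on the sulfonyl sulfur, while compound 1, with 3-methylphenyl, alone gives a number: the limit of > 5000 nM in this assay, at which 2 of the 3 values shown sit.

The step between compound 2 and compound 3 cannot be read, so any difference between the two imidazole attachments remains hidden behind the limit. Also open, from the compounds shown here alone, is whether another ring on the same sulfonyl sulfur, such as an unsubstituted phenyl, a pyridine or a thiophene, would come closer to compound 1, which gives 25 nM, and so show whether the 3-methyl group or the phenyl ring itself matters more.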